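Reversing the amide and swapping halogens on a chromone series

The source may report more compounds than this note shows. Statements on the series, on what has been measured and on what is new or still open speak of the compounds shown alone.

Measured so far:
compound 1 `COc1cc2oc(-c3cccc(NC(=O)c4ccc(Cl)cc4)c3)cc(=O)c2c(OC)c1OC` gives 51.1%
compound 2 `COc1cc2oc(-c3cccc(NC(=O)c4ccc(Br)cc4)c3)cc(=O)c2c(OC)c1OC` gives 63.6%
compound 3 `COc1cc2oc(-c3cccc(C(=O)Nc4ccc(Cl)cc4)c3)cc(=O)c2c(OC)c1OC` gives 129%

In a functional assay on RXF 393 cells (Homo sapiens) for inhibition, read by sulforhodamine B assay, tested at 10 uM (a higher number here means more inhibition at the concentration tested (going by the name of the read-out), a lower number less inhibition), compound 3 stands highest. Compound 3 differs from compound 1 in the orientation of the amide link: (4-chlorophenyl)carbamoyl in place of ((4-chlorophenyl)carbonyl)amino on an aromatic carbon, and the step is a number 77.9 percentage points higher from compound 1 to compound 3 (beyond the scatter). Within the other orientation, compound 2 differs from compound 1 by bromo in place of chloro on an aromatic carbon, giving a number 12.5 percentage points higher from compound 1 to compound 2 (beyond the scatter).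

Compound 4 `COc1cc2oc(-c3cccc(C(=O)Nc4ccc(Br)cc4)c3)cc(=O)c2c(OC)c1OC` is not yet measured. It differs from compound 3 by bromo in place of chloro on an aromatic carbon, the same change as from compound 1 to compound 2, made at a place described in the same words. Because a number 12.5 percentage points higher from compound 1 to compound 2 (beyond the scatter) was only modest, the step from compound 3 to compound 4 is expected to be small too, estimated at a number 3 percentage points higher from compound 3 to compound 4 (within the scatter). Compound 4 is therefore expected to reach about 132%, likely between 105% and 155%.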

Compound 4, a percentage reported as inhibition, at one concentration (the size of the read-out at that concentration, not a potency): "active" (no number reported)
No number was reported for compound 4; there is nothing to compare the estimate with.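

Within the data shown here, compound 4 is recorded only as active, with no number, and no step from compound 3 to compound 4 can be read; no other data here bear on this result. From the compounds shown here alone, whether bromo in place of chloro changes inhibition when the amide runs this way round stays open.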